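The source may hold more compounds than are shown below. What is called first, only, known or untested is meant among the compounds shown, and "the series" means these compounds.

Measured so far:
Compound 1 `O=C(N1CCN(C(=O)N(c2ccccc2)c2ccccc2)CC1)N(c1ccccc1)c1ccccc1`: in an assay for inhibition of Type-2 angiotensin II receptor (Rattus norvegicus) (on this read-out higher numbers stand for weaker inhibition and lower numbers for stronger inhibition), compound 1 gives 37 nM.
Compound 2 `CC1CN(C(=O)N(c2ccccc2)c2ccccc2)CCN1C(=O)N(c1ccccc1)c1ccccc1`: in this assay compound 2 gives 15 nM.

Among these two numbers compound 2 stands lowest, and its only neighbour is compound 1, separated from it by a step that lies beyond the scatter: a 2.5-fold lower number from compound 1 to compound 2 (0.39 log units; beyond the scatter). That single step is the whole of what is known about adding a methyl group to the saturated ring of the shared core.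

Compound 3 `CC1CN(C(=O)N(c2ccccc2)c2ccccc2)C(C)CN1C(=O)N(c1ccccc1)c1ccccc1` repeats that same kind of change once more on the core of compound 2. The difference is methyl in place of hydrogen on a saturated ring carbon. Within the data shown here, only one measured step bears on this: the one from compound 1 to compound 2, which was modest in size and went toward a lower number. A second methyl group at a comparable place on the same ring is expected to behave in a similar way, so in this assay a further small move toward a lower number is expected, though one that may not clear the scatter. For compound 3 the expected value is 10 nM, with a range from 4 nM to 30 nM, which means a step of a 1.5-fold lower number from compound 2 to compound 3 (0.18 log units; within the scatter).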

Compound 3, half-maximal inhibitory concentration: 10 nM
The estimate for compound 3 equals the measured number at the digits printed; low and high end bracket the measured number.
By their numbers in this assay, from the lowest: compounds 3 and 2 (each within the scatter of the next); then compound 1.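

In this assay, a methyl group in place of hydrogen on this saturated ring carbon, three ring bonds from the ring atom that bears a methyl group, gives a 1.5-fold lower number from compound 2 to compound 3 (0.18 log units; within the scatter), so the two compounds cannot be told apart and the added methyl group costs nothing measurable, with compound 3 at 10 nM. The same kind of change earlier gave a 2.5-fold lower number from compound 1 to compound 2 (0.39 log units; beyond the scatter), so on this ring the exchange does not clear the scatter every time: one of its two steps lies beyond the scatter and the other within it. No measurement at hand explains why the two steps differ in size.

The compounds shown leave open whether a larger or different group on this ring carbon, such as an ethyl group, a hydroxymethyl group or an amine, would give a step beyond the scatter in this assay. They also leave open whether a second methyl group would give a different result on another saturated ring carbon of the shared core.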